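A few compounds are considered here, and "the series" means these few. Any claim that something is new, unique, unknown or untested is made for them only; others in the source may bear on it.

Measured compounds: compound 1 `O=C(OC1CCC(CN2CCN(c3cc(=O)c4cc(C(F)(F)F)cc([N+](=O)[O-])c4s3)CC2)CC1)C1CCCCC1` with 2.8%; compound 2 `O=C(OC1CCC(CN2CCN(c3cc(=O)c4cc(C(F)(F)F)cc([N+](=O)[O-])c4s3)CC2)CC1)c1ccccc1` with 56.4%.

In an ADME assay on cells (Hepatocyte, Homo sapiens) for metabolic stability, with a stated time of 30 min (a higher number here means that more of the compound is left, a lower number that less of the compound is left), compound 1 gives 2.8%, the lowest of the two numbers, while compound 2 gives 56.4%. Among the compounds with values here, the single measured step, a number 53.6 percentage points higher from compound 1 to compound 2 (beyond the scatter), bears directly on the change to compound 3 `O=C(OC1CCC(CN2CCN(c3cc(=O)c4cc(C(F)(F)F)cc([N+](=O)[O-])c4s3)CC2)CC1)c1ccc(C(F)(F)F)cc1`, which is 4-(trifluoromethyl)phenyl in place of cyclohexyl on a carbonyl carbon. Because that step a number 53.6 percentage points higher from compound 1 to compound 2 (beyond the scatter) was large and the present change again places a six-membered aromatic ring on the carbonyl carbon, a step up of similar size is expected, a number 52.2 percentage points higher from compound 1 to compound 3 (beyond the scatter). Compound 3 is therefore estimated at 55%, between 25% and 85%.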

Compound 3, percent of the compound remaining: 5.2%
Estimate against measurement, compound 3: 49.8 percentage points above; measured number outside the range, below it.
By their numbers in this assay, from the lowest: compounds 1 and 3 (each within the scatter of the next); then compound 2.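

In this assay, an aromatic ring on the carbonyl carbon does not by itself bring the higher number: 4-(trifluoromethyl)phenyl in place of cyclohexyl gives a number 2.4 percentage points higher from compound 1 to compound 3 (within the scatter). Trifluoromethyl in place of hydrogen on an aromatic carbon alone gives a number 51.2 percentage points lower from compound 2 to compound 3 (beyond the scatter), so among these compounds the outcome turns on that one substituent and not on the ring alone. No measured evidence accounts for this result.

On these data alone, whether a methoxy group or a single fluorine atom on the ring would keep the number of compound 2 stays open. So does whether trifluoromethyl on another ring carbon would give the same result.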